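Amide aryl variation in a bis-benzylidene dienone series

The compounds below may be only part of what the source reports. "The series", "measured", "known", "first", "only" and "open" are said of these compounds alone.

Among the measured compounds shown here, compound 3 `Cc1cccc(C)c1NC(=O)/C=C/C(=O)N1C/C(=C\c2ccc([N+](=O)[O-])cc2)C(=O)/C(=C/c2ccc([N+](=O)[O-])cc2)C1` gives the lowest number of the three measured so far in a functional assay on L1210 cells (Mus musculus) for cytotoxicity (on this read-out lower numbers stand for stronger inhibition and higher numbers for weaker inhibition), at 690 nM. Compound 1 `O=C(/C=C/C(=O)N1C/C(=C\c2ccccc2)C(=O)/C(=C/c2ccccc2)C1)Nc1ccccc1` gives 3600 nM in this assay, and compound 2 `Cc1ccc(NC(=O)/C=C/C(=O)N2C/C(=C\c3ccc([N+](=O)[O-])cc3)C(=O)/C(=C/c3ccc([N+](=O)[O-])cc3)C2)cc1C` gives 4900 nM. For the measured compounds named here, the one step between measured compounds that differ in a single place is a 7.1-fold lower number from compound 2 to compound 3 (0.85 log units; beyond the scatter). Compound 1 differs from compounds 2 and 3 in more than one place, so its number is taken only as it stands.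

Compound 4 `Cc1ccc(NC(=O)/C=C/C(=O)N2C/C(=C\c3ccc([N+](=O)[O-])cc3)C(=O)/C(=C/c3ccc([N+](=O)[O-])cc3)C2)cc1` is the next to be measured. Its difference from compound 3: 4-methylphenyl in place of 2,6-dimethylphenyl on an amide-type nitrogen. Going by the values given here, the 4-methylphenyl that enters resembles the 3,4-dimethylphenyl of compound 2 more closely than the 2,6-dimethylphenyl it replaces, so the step that bears on it is the one from compound 2 to compound 3, read in reverse. Among the compounds with values here, since that step gave a marked fall in number, undoing most of it is expected to raise the number again, in the direction of compound 2, though with only one methyl group present the return need not be complete. Compound 4 is therefore estimated at 3000 nM in this assay, within a range of 1000 nM to 9000 nM, which means an expected step of a 4.3-fold higher number from compound 3 to compound 4 (0.64 log units; beyond the scatter).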

Compound 4, half-maximal inhibitory concentration: 4400 nM
Compound 4: middle estimate off by 1.5-fold (0.17 log units), on the low side; measured number inside the range.
By their numbers in this assay, from the lowest: compound 3; then compounds 1, 4 and 2 (each within the scatter of the next).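

In this assay the change to 4-methylphenyl on the amide-type nitrogen gives a 6.4-fold higher number from compound 3 to compound 4 (0.80 log units; beyond the scatter), so a second replacement of the 2,6-dimethylphenyl, after the 3,4-dimethylphenyl behind a 7.1-fold lower number from compound 2 to compound 3 (0.85 log units; beyond the scatter), also goes with a higher number. The comparison of the two groups that lack the 2,6-dimethyl pattern gives a 1.1-fold lower number from compound 2 to compound 4 (0.05 log units; within the scatter), so the extra methyl of the 3,4-dimethylphenyl makes no readable difference, and among these three compounds on the shared core only compound 3 stands apart from the others. No measurement to hand accounts for why the 2,6-dimethylphenyl stands apart.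

Still open, going by these compounds, is whether both methyl groups of the 2,6-dimethylphenyl are needed for the low number, or whether an aryl group carrying chloro or methoxy groups, or a non-aromatic group such as cyclohexyl on the same nitrogen, would give a similar number. Also open, on these data alone, is whether the same aryl changes would read the same way on the core of compound 1, with its unsubstituted benzylidene groups, since the nitro-bearing compounds alone carry this comparison so far.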